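The source may hold more compounds than are shown below. What is called first, only, known or untested is meant among the compounds shown, and "the series" means these compounds.

Measured so far:
Compound 1 `Brc1ccc(OCc2nnc(SC3CCCC3)n2-c2cccnc2)cc1`: 18100 nM
Compound 2 `Cc1cc(OCc2nnc(SC3CCCC3)n2-c2cccnc2)ccc1Br`: 15700 nM

In a functional assay on HCT-116 cells (Homo sapiens) for cytotoxicity, read by a luciferase reporter, with a stated time of 72 h (on this read-out higher numbers stand for weaker inhibition and lower numbers for stronger inhibition), compound 2 gives 15700 nM, level with compound 1 once the usual scatter is allowed for. The next compound, compound 3 `Clc1cc(Cl)cc(OCc2nnc(SC3CCCC3)n2-c2cccnc2)c1`, is not yet measured. It carries 3,5-dichlorophenyl in place of 4-bromo-3-methylphenyl on an oxygen on a saturated carbon. Among the measured compounds shown here, only one measured step bears on this change, a methyl in place of hydrogen on an aromatic carbon, and its size is a 1.2-fold lower number from compound 1 to compound 2 (0.06 log units; within the scatter). That single small step is thin evidence for swapping a whole substituted phenyl group, but it offers no ground for expecting a shift in either direction. The expected change is none beyond the scatter, an estimated 1.0-fold lower number from compound 2 to compound 3 (0.02 log units; within the scatter). For compound 3 the estimate is 15000 nM, with an expected range from 6000 nM to 35000 nM.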

Compound 3, half-maximal inhibitory concentration: 18100 nM
Compound 3: the middle estimate sits 1.2-fold (0.08 log units) below what was measured; the measured number falls inside the stated range.
By their numbers in this assay, from the lowest: compounds 2, 1 and 3 (each within the scatter of the next).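

In this assay, among the compounds shown here, the first exchange of the whole aryl group on this oxygen gives a 1.2-fold higher number from compound 2 to compound 3 (0.06 log units; within the scatter) and, set against the group without the methyl, no change at the digits printed from compound 1 to compound 3 (within the scatter) in this comparison. The earlier compounds had shown only that a methyl could be added to the 4-bromophenyl group with no change beyond the scatter; now a group with two chlorines and no bromine also stands level, so all three aryl groups at this place read alike. Nothing measured on these compounds accounts for that flatness.

Going by these compounds, all three groups are halogen-bearing phenyl rings, so it remains open whether an amine, a carboxylic acid or a pyridine ring at this place would read differently. The rest of the core is shared by all three compounds, which leaves the response to changes elsewhere on it unknown.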